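This account rests on a few compounds, and the source may have more. Where it says the series, first, only, none or still open, it means among the compounds named here.

Measured so far:
compound 1, `CCCn1c(=O)[nH]c2nc(-c3ccc(S(=O)(=O)N4CCN(c5ccc(Cl)cc5F)CC4)cc3)[nH]c2c1=O`: 1.91 nM
compound 2, `CCCn1c(=O)[nH]c2nc(-c3ccc(S(=O)(=O)N4CCN(Cc5cccc(C)c5)CC4)cc3)[nH]c2c1=O`: 0.397 nM

In an assay on CHO cells for displacement of a labelled ligand from adenosine receptor A2b (Homo sapiens), read by scintillation counting, with a stated time of 75 min, in the presence of a further agent that is not named here (on this read-out lower numbers stand for stronger inhibition and higher numbers for weaker inhibition), compound 1 gives 1.91 nM, the higher of the two numbers measured. Compound 2 gives 0.397 nM in this assay, so a 4.8-fold lower number from compound 1 to compound 2 (0.68 log units; beyond the scatter), a modest step that lies beyond the scatter.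

The compound to be judged next is compound 3, `CCCn1c(=O)[nH]c2nc(-c3ccc(S(=O)(=O)N4CCN(c5ccc(I)cc5)CC4)cc3)[nH]c2c1=O`. It differs from compound 1 as follows: 4-iodophenyl in place of 4-chloro-2-fluorophenyl on an amine nitrogen in a ring. Going by the values given here, the single measured step does not bear on this change directly: there a 3-methylbenzyl replaced the 4-chloro-2-fluorophenyl, whereas here one aromatic ring of carbon only replaces another on the same amine nitrogen in a ring. Among the compounds with values here, no measured pair shows what such an exchange does, so the expectation is a step not beyond the scatter, in no firm direction.

Compound 3 is therefore expected to give about 2 nM in this assay, estimated between 0.7 nM and 6 nM. The step this estimate means is a 1.0-fold higher number from compound 1 to compound 3 (0.02 log units; within the scatter).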

Compound 3, inhibition constant: 0.159 nM
For compound 3 the middle estimate is 13-fold (1.10 log units) above the measured one, and the stated range ends above it.
By their numbers in this assay, from the lowest: compound 3; then compound 2; then compound 1.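

In this assay, exchanging one aromatic ring of carbon only for another on the amine nitrogen in a ring is far from neutral: 4-iodophenyl in place of 4-chloro-2-fluorophenyl gives a 12-fold lower number from compound 1 to compound 3 (1.08 log units; beyond the scatter), so this position responds to what the ring carries, not only to whether a ring is present. The 4-iodophenyl group also goes past the 3-methylbenzyl group, with a 2.5-fold lower number from compound 2 to compound 3 (0.40 log units; beyond the scatter), so a ring attached directly to the nitrogen can outdo this benzyl group, although compound 1, also with a directly attached ring, goes against any general rule of that kind. Nothing measured here explains these differences.

Two things change at once from compound 1 to compound 3, so the compounds shown leave open how much of the step belongs to the iodine and how much to the loss of chlorine and fluorine. A plain phenyl, 4-chlorophenyl or 4-bromophenyl group on the same nitrogen would help to separate these.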